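The compounds below may be only part of what the source reports. "The series", "measured", "known", "first", "only" and "open" are said of these compounds alone.

Measured so far in an ADME assay on HepG2 cells (Homo sapiens) for cytotoxicity, read by MTT assay; a lower number here means a stronger inhibitor, a higher number a weaker inhibitor:
compound 1 `O=C(NC1CCCCC1)Oc1ccc(Cl)cc1C(=O)Nc1ccc(F)cc1`: 21200 nM
compound 2 `O=C(NC1CCCCC1)Oc1ccc(Cl)cc1C(=O)Nc1ccc(Br)cc1`: > 50000 nM (a limit)
compound 3 `O=C(NC1CCCCC1)Oc1ccc(Cl)cc1C(=O)Nc1ccc(Cl)cc1`: > 250000 nM (a limit)

Compound 3 stands at > 250000 nM, which is a limit and not a number. Its true position is therefore open on the upper side.

Compound 4 `O=C(NC1CCCCC1)Oc1ccc(Cl)cc1C(=O)Nc1ccc(C(F)(F)F)cc1` remains to be measured. It carries trifluoromethyl in place of chloro on an aromatic carbon, para to a large group (trifluoromethyl in place of chloro on an aromatic carbon).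

Among the measured compounds shown here, three measured steps concern the same place on the ring. Chloro in place of fluoro gave an at least 11-fold higher number from compound 1 to compound 3 (1.07 log units; beyond the scatter), a large step. Bromo in place of fluoro gave an at least 2.3-fold higher number from compound 1 to compound 2 (0.37 log units; beyond the scatter), an at least modest step. Chloro in place of bromo gave a step that the two limits leave unreadable from compound 2 to compound 3, so the two halogens cannot be ranked.

Trifluoromethyl has no measured precedent in this set, and these steps show only that this place can move the number well beyond the scatter. For the measured compounds named here, the sole true number, compound 1 at 21200 nM, anchors the lower side of the expectation. A further limit in this assay would not be surprising.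

The expected step is an at least 4.1-fold lower number from compound 3 to compound 4 (0.61 log units; beyond the scatter), towards a lower number, though its size is poorly fixed.

For compound 4 the estimated value is 60000 nM, with an expected range from 15000 nM to 300000 nM.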

Compound 4, half-maximal inhibitory concentration: > 125000 nM
Compound 4: only a limit was reported (the forecaster's own chance of this, stated with the estimate: 45%); middle value at least 2.0-fold (0.31 log units) away from the limit.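

In this assay compound 4 gives > 125000 nM, which is a limit and not a number. Trifluoromethyl in place of fluoro gives an at least 5.8-fold higher number from compound 1 to compound 4 (0.77 log units; beyond the scatter), so all three replacements of fluoro shown at this place, para to a large group, lie on the higher side of compound 1, and the group with 4 heavy atoms behaves in this respect like bromo and chloro. The steps from compound 2 to compound 4 and from compound 3 to compound 4 cannot be read, so trifluoromethyl cannot be ranked against either halogen.

Among the compounds shown here, compound 1 remains the only compound with a true number, and the positions of compound 2, compound 3 and compound 4 stay open on the upper side. Also open, on these data alone, is whether another group at this place, such as an amine, a methoxy group or a carboxylic acid, would give a true number in this assay and so allow a real ranking of the substituents.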